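The source may report more compounds than this note shows. Statements on the series, on what has been measured and on what is new or still open speak of the compounds shown alone.

Measured in a functional assay on SMMC-7721 cells (Homo sapiens) for inhibition, read by CCK-8 assay, with a stated time of 72 h, tested at 8 uM; on this read-out lower numbers stand for less inhibition of growth and higher numbers for more inhibition of growth at the one concentration tested:
- Compound 1 `COc1ccc(SCc2ccc(/C=C/C(=O)Nc3ccccc3N)cc2)cc1OC`: 44.6%
- Compound 2 `CCc1ccc(SCc2ccc(/C=C/C(=O)Nc3ccccc3N)cc2)cc1`: 19.5%
- Compound 3 `Nc1ccccc1NC(=O)/C=C/c1ccc(CSc2ccc(F)cc2)cc1`: 15.4%

Compound 3 sits at the low end of this small set, level with its nearest neighbour (a number 4.1 percentage points lower from compound 2 to compound 3 (within the scatter)) and clearly apart from the dimethoxy compound (a number 29.2 percentage points lower from compound 1 to compound 3 (beyond the scatter)). Compound 4 `Nc1ccccc1NC(=O)/C=C/c1ccc(CSCCc2ccccc2)cc1` brings phenethyl in place of 4-fluorophenyl on a sulfur. Within the data shown here, no measured compound carries phenethyl there, so no step tests this change directly. The larger steps, a number 25.1 percentage points lower from compound 1 to compound 2 (beyond the scatter) and a number 29.2 percentage points lower from compound 1 to compound 3 (beyond the scatter), both leave 3,4-dimethoxyphenyl, which compound 4 lacks. The closer guide is the small step, a number 4.1 percentage points lower from compound 2 to compound 3 (within the scatter). No step beyond the scatter is therefore expected, and the estimated change is a number 5.6 percentage points higher from compound 3 to compound 4 (within the scatter). For compound 4 the estimated value is 21%, with an expected range from 8% to 40%.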

Compound 4, percent growth inhibition at one concentration: 15.8%
Beside the measured number, compound 4's estimate is 5.2 percentage points above it; the range from low to high includes it.
By their numbers in this assay, from the lowest: compounds 3, 4 and 2 (each within the scatter of the next); then compound 1.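

In this assay, phenethyl on the sulfur reads level with 4-fluorophenyl (a number 0.4 percentage points higher from compound 3 to compound 4 (within the scatter)) and with 4-ethylphenyl (a number 3.7 percentage points lower from compound 2 to compound 4 (within the scatter)), while 3,4-dimethoxyphenyl stays apart (a number 28.8 percentage points lower from compound 1 to compound 4 (beyond the scatter)). Among the four compounds, only the 3,4-dimethoxyphenyl group therefore separates from the rest, and the change to phenethyl does not move the number. Nothing available here explains this level reading.

The compounds shown leave open whether a single methoxy group or a 3,4-dimethoxyphenethyl group on the sulfur would match compound 1.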